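The source may hold more compounds than are shown below. What is called first, only, known or untested is meant among the compounds shown, and "the series" means these compounds.

In a physicochemical assay for lipophilicity, using the shake flask method, measured as octanol-water partition (a lower number here means a more polar compound, a higher number a more lipophilic compound), compound 1 (`COc1cc(C2=NN(c3ccc(C#N)c(Cl)c3)[C@@H](C3CCCC3)C2)ccc1C(=O)O`) gives 2.1 and compound 2 (`COc1nc(C2=NN(c3ccc(C#N)c(C)c3)[C@@H](C3CCCC3)C2)ccc1C(=O)N(C)C`) gives 3.5 as the reference points for this series. Compound 3 (`COc1nc(C2=NN(c3ccc(C#N)c(C)n3)[C@@H](C3CCCC3)C2)ccc1C(N)=O`) gives 3.4 on the same scale, within the scatter of compound 2 and beyond the scatter above compound 1. Compound 4 (`COc1nc(C2=NN(c3ccc(C#N)c(C)n3)[C@@H](C3CCCC3)C2)ccc1C(=O)N(C)C`) has dimethylamino in place of amino on a carbonyl carbon relative to compound 3. Going by the values given here, no measured pair isolates this change, so the expectation is tentative. Dimethylcarbamoyl also occurs in compound 2 at 3.5 so only a small upward step in this assay is expected, probably not beyond the scatter. The expected step is a number 0.20 log units higher from compound 3 to compound 4 (within the scatter) on this reasoning. For compound 4 the estimated value is 3.6 (3.2 to 4).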

Compound 4, distribution coefficient: 4.1
Estimate against measurement, compound 4: 0.50 log units below, and the stated range ends below it.
By their numbers in this assay, from the lowest: compound 1; then compounds 3 and 2 (each within the scatter of the next); then compound 4.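

Dimethylamino in place of amino on a carbonyl carbon gives a number 0.70 log units higher from compound 3 to compound 4 (beyond the scatter) in this assay and is the first single change at this position with a reading. With dimethylcarbamoyl held fixed, 5-cyano-6-methylpyridin-2-yl in place of 4-cyano-3-methylphenyl on an amine nitrogen in a ring gives a number 0.60 log units higher from compound 2 to compound 4 (beyond the scatter) in this assay as well, so both places move the number. No available evidence bears on the origin of either step.

Where methylcarbamoyl falls between carbamoyl and dimethylcarbamoyl remains open. Also open, as far as these compounds go, is whether the carbamoyl step holds with 4-cyano-3-methylphenyl on the ring nitrogen.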